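Trimming an Aromatic Side Group on a Hydroxamic Acid

The compounds below may be only part of what the source reports. "The series", "measured", "known", "first", "only" and "open" are said of these compounds alone.

Compound 1, `O=C(/C=C/c1ccc(/C=C/C(=O)c2cccc(Cl)c2)o1)NO`: 12900 nM
Compound 2, `CC(C)c1ccc(C(=O)/C=C/c2ccc(/C=C/C(=O)NO)o2)cc1`: 4890 nM

Both compounds were tested in an assay on isolated protein for inhibition of histone deacetylase 4 (Homo sapiens), read by fluorescence; a lower number here means a stronger inhibitor, a higher number a weaker inhibitor. Compound 2 stands at the lower of the two numbers, and the gap from compound 1 to compound 2 lies beyond the usual scatter of this assay, so compound 2 is the stronger inhibitor of the pair.

Compound 3, `Cc1ccc(C(=O)/C=C/c2ccc(/C=C/C(=O)NO)o2)cc1`, keeps the whole framework of compound 2 and differs in one place only: methyl in place of isopropyl on an aromatic carbon. Among the compounds with values here, no pair of measured compounds shows the effect of such a change, so the expectation rests on the general observation that swapping one small group for another at a single position usually moves this assay only modestly. A small shift toward a weaker number, or none beyond the scatter, is expected. The step from compound 2 to compound 3 in this assay is estimated at a 1.4-fold higher number from compound 2 to compound 3 (0.16 log units; within the scatter). For compound 3 the estimated value in this assay is 7000 nM, with a likely range from 2500 nM to 20000 nM.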

Compound 3, half-maximal inhibitory concentration: 1100 nM
For compound 3 the middle estimate is 6.4-fold (0.80 log units) above the measured one; the whole stated range lies above it.
By their numbers in this assay, from the lowest: compound 3; then compound 2; then compound 1.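

In this assay, trimming isopropyl to methyl on the aromatic carbon para to a large group gives a 4.4-fold lower number from compound 2 to compound 3 (0.65 log units; beyond the scatter), so this position is not indifferent to which small carbon group it carries, and the smaller group goes with the stronger inhibitor. Exchanging the whole side group, 4-methylphenyl in place of 3-chlorophenyl on a carbonyl carbon, gives a 12-fold lower number from compound 1 to compound 3 (1.07 log units; beyond the scatter), which makes compound 3 the strongest inhibitor of the three. Nothing measured here explains why methyl outperforms isopropyl at this place.

As far as these compounds go, two groups at one position do not establish a trend, so it remains open how hydrogen, ethyl or methoxy would behave there. From the compounds shown here alone, compound 1 differs from compound 3 in both the substituent and its place on the ring, so the separate contributions of these two features also remain open.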